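The compounds below may be only part of what the source reports. "The series", "measured", "known", "first", "only" and "open" are said of these compounds alone.

Measured compounds:
- Compound 1, `COc1ccc(S(=O)(=O)c2cnc3ccc(Cl)cc3c2N2CCC(C)CC2)cc1Cl`: 46%
- Compound 2, `COc1ccc(S(=O)(=O)c2cnc3ccc(Cl)cc3c2N2CCC(C)CC2)cc1OC`: 61%
- Compound 3, `CC1CCN(c2c(S(=O)(=O)c3ccc(F)c(F)c3)cnc3ccc(Cl)cc23)CC1`: 72%

In an assay on isolated protein for displacement of a labelled ligand from metabotropic glutamate receptor 5 (Homo sapiens), with a stated time of 60 min, tested at 1 uM (a higher number here means more inhibition at the concentration tested (going by the name of the read-out), a lower number less inhibition), compound 3 stands highest of the three measured numbers; its step to compound 2 and its step to compound 1 are both beyond the scatter. The two steps that lead to it, a number 26 percentage points higher from compound 1 to compound 3 (beyond the scatter) and a number 11 percentage points higher from compound 2 to compound 3 (beyond the scatter), both exchange the whole ring on the sulfonyl sulfur, and a number 15 percentage points higher from compound 1 to compound 2 (beyond the scatter) exchanges one group on that ring for another.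

Compound 4, `CC1CCN(c2c(S(=O)(=O)c3cccc(F)c3)cnc3ccc(Cl)cc23)CC1`, is not yet measured. It differs from compound 3 by one change: hydrogen in place of fluoro on an aromatic carbon. Read one bond further out, the change is 3,4-difluorophenyl to 3-fluorophenyl.

Among the compounds with values here, none of the measured steps removes a group on this ring; all three replace one group or ring by another, and each moved this assay only modestly. The change to compound 4 is the smallest of the four, so for compound 4 a step of a number 7 percentage points lower from compound 3 to compound 4 (within the scatter) is expected, within the scatter or only a little beyond it, in either direction. Compound 4 is estimated at 65%, with a range from 45% to 85%.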

Compound 4, a percentage reported as inhibition, at one concentration (the size of the read-out at that concentration, not a potency): 58%
For compound 4 the middle estimate is 7 percentage points above the measured one, within the range that was stated.
By their numbers in this assay, from the lowest: compound 1; then compounds 4 and 2 (each within the scatter of the next); then compound 3.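

In this assay, a number 14 percentage points lower from compound 3 to compound 4 (beyond the scatter) comes from removing a single fluoro, ortho to the remaining fluoro group, and leaving hydrogen in its place. Within the data shown here, this is the first step here that takes a group away rather than exchanging it, and it shows that this one atom moves the read-out beyond the scatter. Set against the other ring types, 3-fluorophenyl gives a number 12 percentage points higher from compound 1 to compound 4 (beyond the scatter) and stays clear of the 3-chloro-4-methoxyphenyl compound, while a number 3 percentage points lower from compound 2 to compound 4 (within the scatter) leaves it within the scatter of the 3,4-dimethoxyphenyl compound. Nothing available explains why this fluoro matters.

From the compounds shown here alone, it remains open whether a methyl, a nitrile or an amine at this place would match fluoro or hydrogen. Going by these compounds, it is also open whether removing the other fluoro group would give a step of similar size.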